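Series notes: amide variation on the shared core

The source may hold more compounds than are shown below. What is called first, only, known or untested is meant among the compounds shown, and "the series" means these compounds.

Compound 1 `O=C(Nc1ccc(Cl)c(-c2nnc3c(Cl)cccn23)c1)c1ccccc1` is measured in a functional assay on MDA-MB-231 cells (Homo sapiens) for antiproliferative activity, read by MTT assay, with stated times of 72 h and 4 h (a lower number here means a stronger inhibitor, a higher number a weaker inhibitor), and gives 58200 nM, the lowest of the two numbers shown, with compound 2 `O=C(Nc1ccc(Cl)c(-c2nnc3c(Cl)cccn23)c1)c1ccccc1Cl` giving 59900 nM. For compound 3 `CS(=O)(=O)c1cccc(C(=O)Nc2ccc(Cl)c(-c3nnc4c(Cl)cccn34)c2)c1` only a limit of the assay is recorded, > 100000 nM, as described by the limit of > 100000 nM in this assay, at which 1 of the 3 values shown sits. The change from compound 1 to compound 4 `O=C(Nc1ccc(Cl)c(-c2nnc3c(Cl)cccn23)c1)c1cccnc1Cl` is 2-chloropyridin-3-yl in place of phenyl on a carbonyl carbon. The step of a 1.0-fold higher number from compound 1 to compound 2 (0.01 log units; within the scatter) is the closest comparison, as chloro enters on the same carbonyl-bound ring, and it stayed within the scatter; the step of an at least 1.7-fold higher number from compound 1 to compound 3 (0.23 log units; that floor lies within the scatter) gives a floor that also lies within the scatter. No step beyond the scatter is therefore expected for compound 4 in this assay, and its value is estimated as 70000 nM with a range of 30000 nM to 150000 nM, meaning an expected step of a 1.2-fold higher number from compound 1 to compound 4 (0.08 log units; within the scatter).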

Compound 4, half-maximal inhibitory concentration: 89700 nM
Beside the measured number, compound 4's estimate is 1.3-fold (0.11 log units) below it, and the stated range covers the measured number.
By their numbers in this assay, from the lowest: compounds 1, 2 and 4 (each within the scatter of the next). At a limit, above all of these: compound 3.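

In this assay, the first ring hetero atom at this position, with 2-chloropyridin-3-yl on the carbonyl carbon, gives no step beyond the scatter against either aromatic ring: a 1.5-fold higher number from compound 1 to compound 4 (0.19 log units; within the scatter) and a 1.5-fold higher number from compound 2 to compound 4 (0.18 log units; within the scatter). The second step isolates the ring nitrogen, with the chloro present on both sides. Compound 3 remains a limit, so only a floor can be read, an at least 1.1-fold lower number from compound 3 to compound 4 (0.04 log units; that floor lies within the scatter), and it rests on this limit: the limit of > 100000 nM in this assay, at which 1 of the 4 values shown sits.

The compounds shown leave open whether any group on this carbonyl carbon gives a step beyond the scatter. Going by these compounds, an amine, a carboxylic acid or a longer chain on the ring remains untested here.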